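Mirror-image Thiourea: Expected Cytotoxicity of Compound 3

The compounds below may be only part of what the source reports. "The series", "measured", "known", "first", "only" and "open" are said of these compounds alone.

Compound 1 `CC(C)[C@H](NC(=S)NCc1ccccc1)c1nc2ccccc2[nH]1` is a thiourea with a benzyl group on one nitrogen. In a functional assay on MCF7 cells (Homo sapiens) for cytotoxicity, read by MTT assay (on this read-out higher numbers stand for weaker inhibition and lower numbers for stronger inhibition), compound 1 gives 57800 nM, the highest of the two numbers recorded here; its closest neighbour is compound 2 `CC(C)[C@H](NC(=S)Nc1ccccc1)c1nc2ccccc2[nH]1`, which in this assay gives 9800 nM. Among the compounds with values here, the one measured step, a 5.9-fold lower number from compound 1 to compound 2 (0.77 log units; beyond the scatter), comes from swapping the benzyl group for a phenyl group on that nitrogen.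

Compound 3 `CC(C)[C@@H](NC(=S)NCc1ccccc1)c1nc2ccccc2[nH]1` is the mirror image of compound 1: the two compounds have the same atoms and bonds and differ only in configuration as drawn: 1 of 1 stereo elements differ; a stereocentre at a saturated chain carbon is drawn S in compound 1 and R in compound 3. This change touches no group at all, so the benzyl-to-phenyl step offers no direct guide to it. Nothing measured here shows how the two configurations compare, and either could give the lower number, or neither beyond the scatter.

With no guidance in any direction, compound 3 is expected to sit close to compound 1, so the estimated step is a 1.1-fold lower number from compound 1 to compound 3 (0.02 log units; within the scatter), with a wide range. Compound 3 is therefore estimated at 55000 nM in this assay, between 18000 nM and 170000 nM.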

Compound 3, half-maximal inhibitory concentration: 11100 nM
For compound 3 the middle estimate is 5.0-fold (0.70 log units) above the measured one; measured number outside the range, below it.
By their numbers in this assay, from the lowest: compounds 2 and 3 (each within the scatter of the next); then compound 1.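

The stereocentre at the saturated chain carbon turns out to matter in this assay: with the benzyl group held in place, drawing this centre R rather than S gives a 5.2-fold lower number from compound 1 to compound 3 (0.72 log units; beyond the scatter). Within the data shown here, the earlier compounds showed only that the group on the thiourea nitrogen counts, with a 5.9-fold lower number from compound 1 to compound 2 (0.77 log units; beyond the scatter); now a change that adds and removes no atoms also moves the number beyond the scatter. This difference can be assigned to the configuration at this one carbon because nothing else separates the two compounds: the fact that compounds 1 and 3 differ only in the configuration as drawn

From the compounds shown here alone, whether the R configuration also gives the lower number when a phenyl group sits on the thiourea nitrogen stays open, since the two configurations can be compared here only with the benzyl group in place. Also open, going by these compounds, are why this configuration gives the lower number in cells, and whether the same difference would remain with another group on the benzyl ring, such as an amine or a carboxylic acid, or with a longer chain between the ring and the nitrogen.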